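A few compounds are considered here, and "the series" means these few. Any claim that something is new, unique, unknown or untested is made for them only; others in the source may bear on it.

Of the compounds shown here, two have been measured for inhibition of the enzyme, both at one fixed concentration. Compound 1 `O=S(=O)(c1cccc(O)c1)N1CCN(c2cccc(O)c2)CC1` carries a hydroxy group on each of its two aromatic rings. In an assay on microsomes from placenta for inhibition of 17-beta-hydroxysteroid dehydrogenase type 2 (Homo sapiens), read by HPLC, with a stated time of 20 min, tested at 1 uM (a lower number here means less inhibition, a higher number more inhibition at the concentration tested (going by the name of the read-out)), compound 1 gives 25%. Compound 2 `COc1cccc(S(=O)(=O)N2CCN(c3ccc(F)c(OC)c3)CC2)c1`, which bears methoxy groups in place of both hydroxy groups and an added fluorine, gives in this assay a read-out of 15%. Compound 1 has the higher of the two numbers recorded so far, but the gap to compound 2 lies within the usual scatter of repeated measurements, so the two cannot be set in order.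

Compound 3 `O=S(=O)(c1cccc(O)c1)N1CCN(c2ccc(F)c(O)c2)CC1` has not yet been measured. It differs from compound 1 by one change: fluoro in place of hydrogen on an aromatic carbon. Within the data shown here, no measured pair in this set isolates this change, so its effect has to be guessed. The step from compound 1 to compound 3 in this assay is expected to be small, as no change at the digits printed from compound 1 to compound 3 (within the scatter), and may not exceed the scatter in either direction. Compound 3 is thus expected to give about 25%, with a plausible range from 8% to 45%.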

Compound 3, a percentage reported as inhibition, at one concentration (the size of the read-out at that concentration, not a potency): 48%
The estimate for compound 3 lay 23 percentage points below the measured number, and the stated range ends below it.
By their numbers in this assay, from the lowest: compounds 2 and 1 (each within the scatter of the next); then compound 3.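

In this assay, among these compounds, adding a single fluoro to the 3-hydroxyphenyl ring, ortho to a hydroxy group and para to a large group, gives a number 23 percentage points higher from compound 1 to compound 3 (beyond the scatter), the only change in this set that can be read on its own. The position therefore responds to substitution: one added heavy atom, counted with no hydrogen-bond donors or acceptors, is enough to move the read-out past the usual variation between repeated measurements, so this carbon need not stay unsubstituted. Nothing available on these compounds accounts for the rise, and its cause remains unknown.

From the compounds shown here alone, what stays open is whether the rise belongs to fluoro specifically or would also appear with another small group at this carbon, such as chloro or methyl, and whether a fluoro on the other aromatic ring, the one attached to the sulfonyl group, would act in the same way. Since each number is a percentage at one concentration rather than a potency, the compounds shown also leave open how the step would look across a range of concentrations.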